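From 4-methoxyphenyl to phenyl on compound 1

This account rests on a few compounds, and the source may have more. Where it says the series, first, only, none or still open, it means among the compounds named here.

Compound 1 `COc1ccc(C(=O)Nc2nnc(/C=C/c3cc(OC)c(OC)c(OC)c3Br)s2)cc1` - 560 nM
Compound 2 `COc1cc(/C=C/c2nnc(NC(=O)c3cccc(O)c3)s2)cc(OC)c1OC` - 460 nM

For the measured compounds named here, only two compounds have numbers so far, both from a functional assay on MCF7 cells (Homo sapiens) for antiproliferative activity, read by MTT assay, with a stated time of 48 h; on this read-out lower numbers stand for stronger inhibition and higher numbers for weaker inhibition. In this test compound 1 gives 560 nM and compound 2 gives 460 nM as its value, and the two numbers lie within the usual scatter of each other. Going by the values given here, compound 1 therefore cannot be separated from the only other measured compound.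

Compound 3 `COc1cc(/C=C/c2nnc(NC(=O)c3ccccc3)s2)c(Br)c(OC)c1OC` has yet to be measured. It differs from compound 1 in one place, with hydrogen in place of methoxy on an aromatic carbon, para to a large group (hydrogen in place of methoxy on an aromatic carbon). The same difference reads as 4-methoxyphenyl to phenyl. Among the compounds with values here, no measured pair shows what this change does, so the data offer no direction for it. In this assay the expectation is therefore for no shift beyond the scatter, with neither direction favoured. The expected size of the change is small (a 1.1-fold lower number from compound 1 to compound 3 (0.03 log units; within the scatter)) and its sign is uncertain. Compound 3 is estimated at 520 nM in this test, with an expected range from 180 nM to 1500 nM for the measurement.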

Compound 3, half-maximal inhibitory concentration: 290 nM
For compound 3 the middle estimate is 1.8-fold (0.25 log units) above the measured one, within the range that was stated.
By their numbers in this assay, from the lowest: compounds 3, 2 and 1 (each within the scatter of the next).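

In this assay, for the compounds shown here, the exchange of 4-methoxyphenyl for phenyl gives a 1.9-fold lower number from compound 1 to compound 3 (0.29 log units; within the scatter) and so supplies the first direct reading of hydrogen in place of methoxy on this aromatic carbon. The step stays inside the scatter, so compound 1 and compound 3 cannot be separated, and the pair gives no sign that the methoxy group at this place is needed to keep a value of this order in this test. Nothing available here speaks to why the two compounds read alike.

From the compounds shown here alone, this single pair gives one reading at one place, so it cannot show how far the position tolerates other groups: whether an amine, a carboxylic acid or a longer chain such as ethoxy on this carbon would read alike or move the number beyond the scatter remains open. Going by these compounds, it also remains open whether hydrogen in place of methoxy would read the same way with other parts of compound 1 altered.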